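Dropping the Hydroxy: Tolerability of Compound 3 Expected Unchanged

The compounds below may be only part of what the source reports. "The series", "measured", "known", "first", "only" and "open" are said of these compounds alone.

Measured so far:
Compound 1, `O=C(O)c1ccc(Cn2cccc2)cc1`, 498000 nM
Compound 2, `O=C(O)c1cc(-n2cccc2)ccc1O`, 493000 nM

Two compounds have been run in an ADME assay on MT2 cells (Homo sapiens) for cytotoxicity, read by XTT assay, with a stated time of 4 days; a higher number here means that more compound is tolerated, a lower number that less compound is tolerated. Compound 1, with structure `O=C(O)c1ccc(Cn2cccc2)cc1`, gives 498000 nM. Compound 2, with structure `O=C(O)c1cc(-n2cccc2)ccc1O`, gives 493000 nM. The two numbers lie within the scatter of each other, so compound 2 stands level with compound 1 in this assay; neither can be called better tolerated than the other on this evidence.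

The next compound, compound 3, has structure `O=C(O)c1cccc(-n2cccc2)c1`. It differs from compound 2 in one place: hydrogen in place of hydroxy on an aromatic carbon. The change is small, a single oxygen leaving with no change to the ring framework or to the pyrrole. Because compound 1 gives 498000 nM and compound 2 gives 493000 nM within the scatter of each other despite more substantial differences between them, a step from compound 2 to compound 3 of any size beyond the scatter is not expected in this assay. The expected step is a 1.1-fold lower number from compound 2 to compound 3 (0.04 log units; within the scatter). Compound 3 is therefore estimated at 450000 nM in this assay, with a range from 200000 nM to 900000 nM.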

Compound 3, half-maximal cytotoxic concentration: 302000 nM
Compound 3: middle estimate off by 1.5-fold (0.17 log units), on the high side; the range from low to high includes it.
By their numbers in this assay, from the lowest: compounds 3, 2 and 1 (each within the scatter of the next).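

In this assay, putting hydrogen in place of the hydroxy on the aromatic carbon, which is ortho to a carboxy group and para to a 1H-pyrrol-1-yl group, gives a 1.6-fold lower number from compound 2 to compound 3 (0.21 log units; within the scatter). Among the compounds shown here, this is the first pair here that differs in one place only, so it is the first direct reading of this change, and it shows that this hydroxy, with the hydrogen-bond donor and acceptor counted with it, can leave without a step beyond the scatter in this read-out. No measurement shown bears on what lies behind the size of this step.

From the compounds shown here alone, what remains open is whether other groups on that same aromatic carbon, such as a methoxy group, an amine or a fluorine atom, would also stay within the scatter of compound 2 and compound 3, and whether the same exchange of hydroxy for hydrogen would give a similar step on a different core. The compounds shown also leave open how the numbers would respond if the carboxy group itself gave way to an amide or a methyl ester.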